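The source may report more compounds than this note shows. Statements on the series, on what has been measured and on what is new or still open speak of the compounds shown alone.

Within the data shown here, compound 2 `O=C(C1CC1)N1CCN(c2nc(=O)c3cc(C(F)(F)F)cc([N+](=O)[O-])c3s2)CC1` gives 52.9 ug/mL in a physicochemical assay for solubility, read by HPLC (a lower number here means a less soluble compound, a higher number a more soluble compound), the lowest of the two numbers so far; the nearest is compound 1 `CC(=O)N1CCN(c2nc(=O)c3cc(C(F)(F)F)cc([N+](=O)[O-])c3s2)CC1`, which in this assay gives 83.9 ug/mL. Among the measured compounds shown here, the only step measured, a 1.6-fold lower number from compound 1 to compound 2 (0.20 log units; within the scatter), stays within the scatter. Compound 3 `CCCCC(=O)N1CCN(c2nc(=O)c3cc(C(F)(F)F)cc([N+](=O)[O-])c3s2)CC1` differs from compound 2 in one place: butyl in place of cyclopropyl on a carbonyl carbon. For the measured compounds named here, that step adds one more carbon to the group on the carbonyl carbon, so for compound 3 a somewhat lower number in this assay is expected, a 1.9-fold lower number from compound 2 to compound 3 (0.28 log units; within the scatter), though the one measured step gives little to lean on. The estimate for compound 3 is 28 ug/mL, within 11 ug/mL to 70 ug/mL.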

Compound 3, solubility: 42.5 ug/mL
For compound 3 the middle estimate is 1.5-fold (0.18 log units) below the measured one; low and high end bracket the measured number.
By their numbers in this assay, from the lowest: compounds 3, 2 and 1 (each within the scatter of the next).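

On the carbonyl carbon whose other neighbour is an amide-type nitrogen in a ring, replacing cyclopropyl with butyl, which has no ring, gives a 1.2-fold lower number from compound 2 to compound 3 (0.10 log units; within the scatter) in this assay and so stays within the scatter. Replacing the hydrogen of compound 1's methyl with propyl gives a 2.0-fold lower number from compound 1 to compound 3 (0.30 log units; within the scatter) and also stays within the scatter, so these three compounds cannot be ranked. Nothing here offers a reason for these numbers.

Still open, as far as these compounds go, is whether an amine, a carboxylic acid or a much longer chain at this place would move the number beyond the scatter.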